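A few compounds are considered here, and "the series" means these few. Any claim that something is new, unique, unknown or untested is made for them only; others in the source may bear on it.

Measured in a physicochemical assay for solubility; a higher number here means a more soluble compound, a lower number a less soluble compound:
- Compound 1 `O=C(Nc1ccc([N+](=O)[O-])cc1)c1cc(Cl)ccc1O`: 6.4 ug/mL
- Compound 2 `O=C(Nc1ccc(F)cc1)c1cc(Cl)ccc1O`: 1.6 ug/mL
- Compound 3 `O=C(Nc1ccc(C(F)(F)F)cc1)c1cc(Cl)ccc1O`: < 1 ug/mL, a limit

Compound 3 has only a limit in this assay, not a number. Compound 4 `COc1ccc(NC(=O)c2cc(Cl)ccc2O)cc1` carries methoxy in place of trifluoromethyl on an aromatic carbon. For the measured compounds named here, no measured step makes this exchange. The closest are the swaps on that carbon: a 4.0-fold lower number from compound 1 to compound 2 (0.60 log units; beyond the scatter), an at least 6.4-fold lower number from compound 1 to compound 3 (0.80 log units; beyond the scatter) and an at least 1.6-fold lower number from compound 2 to compound 3 (0.20 log units; that floor lies within the scatter). The first two are modest or larger, while the floor of the third lies within the scatter. A modest rise is therefore expected in this assay, or none beyond the scatter. The expected step is an at least 1.6-fold higher number from compound 3 to compound 4 (0.20 log units; that floor lies within the scatter). The estimate for compound 4 is 1.6 ug/mL, with an expected range of 0.7 ug/mL to 4 ug/mL.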

Compound 4, solubility: 2.8 ug/mL
The estimate for compound 4 lay 1.8-fold (0.24 log units) below the measured number, within the range that was stated.
By their numbers in this assay, from the lowest: compounds 2 and 4 (each within the scatter of the next); then compound 1. At a limit, below all of these: compound 3.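

Compound 3 gives only a limit in this assay: the limit of < 1 ug/mL in this assay, at which 1 of the 4 values shown sits. Methoxy on this aromatic carbon gives a readable number, with an at least 2.8-fold higher number from compound 3 to compound 4 (0.44 log units; beyond the scatter), so that step is known only as a floor. Against the other groups at this position, methoxy shows a 1.8-fold higher number from compound 2 to compound 4 (0.24 log units; within the scatter) and a 2.3-fold lower number from compound 1 to compound 4 (0.36 log units; beyond the scatter), which leaves nitro alone above the other three groups.

The compounds shown leave open how an amine or a carboxylic acid would read on this carbon. They also leave open whether a longer chain in place of methoxy would keep the number.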